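Cytotoxicity Outlook for Compound 4 From Compound 2

A few compounds are considered here, and "the series" means these few. Any claim that something is new, unique, unknown or untested is made for them only; others in the source may bear on it.

Measured compounds:
compound 1, `CCOC(=O)NC(=O)NC1=CS(=O)(=O)O[C@@]12[C@@H](CO[Si](C)(C)C(C)(C)C)O[C@@H](n1cc(C)c(=O)n(C)c1=O)[C@@H]2O[Si](C)(C)C(C)(C)C`, 16000 nM in a functional assay on HEL cells (Homo sapiens) for cytotoxicity, read by microscopy; a higher number here means that more compound is tolerated, a lower number that less compound is tolerated
compound 2, `CCNC(=O)NC1=CS(=O)(=O)O[C@@]12[C@@H](CO[Si](C)(C)C(C)(C)C)O[C@@H](n1cc(C)c(=O)n(C)c1=O)[C@@H]2O[Si](C)(C)C(C)(C)C`, a limit only, >= 3200 nM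
compound 3, `COC(=O)CCNC1=CS(=O)(=O)O[C@@]12[C@@H](CO[Si](C)(C)C(C)(C)C)O[C@@H](n1cc(C)c(=O)n(C)c1=O)[C@@H]2O[Si](C)(C)C(C)(C)C`, a limit only, >= 400000 nM

Of the three, only compound 1 gives a plain number in this assay. The value of compound 2 is a limit of the assay (the limit of >= 3200 nM in this assay, at which 1 of the 3 values shown sits). The value of compound 3 is likewise a limit (the limit of >= 400000 nM in this assay, at which 1 of the 3 values shown sits). So compound 2 stands at a limit, with compound 1 the only compound giving a definite number below it and compound 3 at a far higher limit.

Among the compounds with values here, the one readable step is an at least 25-fold higher number from compound 1 to compound 3 (1.39 log units; beyond the scatter). The step that the limit leaves unreadable from compound 1 to compound 2 and the step that the two limits leave unreadable from compound 2 to compound 3 cannot be sized.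

Compound 4, `CC(=O)NC1=CS(=O)(=O)O[C@@]12[C@@H](CO[Si](C)(C)C(C)(C)C)O[C@@H](n1cc(C)c(=O)n(C)c1=O)[C@@H]2O[Si](C)(C)C(C)(C)C`, differs from compound 2 by methyl in place of ethylamino on a carbonyl carbon. Within the data shown here, none of the measured steps bears on this change: the readable step from compound 1 to compound 3 concerns the substituent on the amine nitrogen, and both steps that involve compound 2 are unreadable. The data thus give no direction for the change, and the starting point, compound 2, is itself only a limit. Compound 4 is expected to give 12000 nM, between 3200 nM and 50000 nM. The expected step is a step that the limit leaves unreadable from compound 2 to compound 4.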

Compound 4, minimum cytotoxic concentration: >= 80000 nM
Compound 4 ended at the assay's limit; the forecaster's own chance of this, stated with the estimate: 40%; middle value at least 6.6-fold (0.82 log units) away from the limit.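

In this assay compound 4 gives >= 80000 nM, which is a limit of the assay and not a number. Even so, this change on the carbonyl carbon yields a readable comparison with the only compound that has a plain value: methyl in place of (ethoxycarbonyl)amino gives an at least 5.0-fold higher number from compound 1 to compound 4 (0.69 log units; beyond the scatter), and with an at least 25-fold higher number from compound 1 to compound 3 (1.39 log units; beyond the scatter) there are now two changes to the group on the amine nitrogen of compound 1 that both raise the number, a pattern that rests on these compounds alone. The steps that link compound 4 to compound 2 and to compound 3 cannot be read, so the swap of ethylamino for methyl still has no size, and the acetamido group can be placed only against the (ethoxycarbonyl)carbamoyl-bearing compound 1.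

The compounds shown leave open how far compound 2, compound 3 and compound 4 would each go past their limits, and so how they rank against one another. They also leave open what a longer chain such as propyl, or a methoxy group, would give on the same carbonyl carbon in this assay.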